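The source may hold more compounds than are shown below. What is called first, only, known or untested is meant among the compounds shown, and "the series" means these compounds.

Measured in a functional assay on MOLT-4 cells (Homo sapiens) for antiproliferative activity, read by MTT assay, with a stated time of 72 h; on this read-out higher numbers stand for weaker inhibition and lower numbers for stronger inhibition:
- compound 1 `O=C1C=C(N2CCN(c3ccccc3Cl)CC2)C(=O)c2ccccc21`: > 50000 nM (a limit, not a number)
- compound 2 `O=C1C=C(N2CCN(c3ccccc3Cl)CC2)C(=O)c2c(O)cccc21`: 27600 nM

Among the compounds with values here, compound 2 carries the only actual number so far, 27600 nM. Compound 1 is known only by a limit, (the limit of > 50000 nM in this assay, at which 1 of the 2 values shown sits).

Compound 3 `Cc1ccccc1N1CCN(C2=CC(=O)c3cccc(O)c3C2=O)CC1` is the next case: methyl in place of chloro on an aromatic carbon, 2-chlorophenyl to 2-methylphenyl. Within the data shown here, the one measured step, an at least 1.8-fold lower number from compound 1 to compound 2 (0.25 log units; that floor lies within the scatter), is a different change, hydroxy in place of hydrogen, and its floor lies within the scatter. Among the measured compounds shown here, no measured step covers the chloro-to-methyl exchange, so the expectation starts from compound 2 at 27600 nM in this assay. The expected step is a 1.0-fold lower number from compound 2 to compound 3 (0.01 log units; within the scatter), and nothing beyond the scatter is anticipated. For compound 3 the estimated value is 27000 nM, with an expected range of 11000 nM to 50000 nM.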

Compound 3, half-maximal inhibitory concentration: > 50000 nM
Compound 3 was reported as a limit; the forecaster's own chance of this, stated with the estimate: 20%; middle value at least 1.8-fold (0.26 log units) from the limit.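

In this assay, this is the first exchange shown on the aromatic ring carrying the chloro group, and methyl in place of chloro gives an at least 1.8-fold higher number from compound 2 to compound 3 (0.25 log units; that floor lies within the scatter). From the compounds shown here alone, only a floor is available for this step, so its true size remains unknown, but methyl brings no lower number at this place. Compound 2, with its chloro group, remains the only compound with an actual number, and the series otherwise rests on a limit: the limit of > 50000 nM in this assay, at which 2 of the 3 values shown sit.

Going by these compounds, it remains open whether a measurable number needs chloro specifically or whether other groups on the same aromatic carbon, such as fluoro, methoxy or an amine, would also give one. Also open, on these data alone, is how large the real gap between chloro and methyl is.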